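Swapping a pyrazole for an indole on the amide

A few compounds are considered here, and "the series" means these few. Any claim that something is new, unique, unknown or untested is made for them only; others in the source may bear on it.

Compound 2 `COc1cc(C(N)=O)cc2nc(NC(=O)c3ccnn3C)n(CCCNC(=O)OCc3ccccc3)c12` carries a 1-methyl-1H-pyrazol-5-yl group on the carbonyl carbon of its amide. In an assay for activation of interferon regulatory factor 3 (Homo sapiens), read by a luciferase reporter, with a stated time of 20 h (a higher number here means that more compound is needed for the effect, a lower number that less compound is needed), compound 2 gives only a limit, > 100000 nM. Compound 1 `COc1cc(C(N)=O)cc2nc(NC(=O)c3ccc4ccccc4n3)n(CCCNC(=O)OCc3ccccc3)c12` bears quinolin-2-yl on a carbonyl carbon instead. In this assay compound 1 likewise gives only a limit, > 100000 nM. The step that the two limits leave unreadable from compound 1 to compound 2 therefore cannot be read, since both values sit at the limit of > 100000 nM in this assay, at which 2 of the 2 values shown sit. The new compound 3 `COc1cc(C(N)=O)cc2nc(NC(=O)c3cc4ccccc4n3C)n(CCCNC(=O)OCc3ccccc3)c12` differs from compound 2 by 1-methyl-1H-indol-2-yl in place of 1-methyl-1H-pyrazol-5-yl on a carbonyl carbon. Among the compounds with values here, the only measured step that bears on this change is the unreadable one, so there is no basis for expecting a gain or a loss in this assay beyond the scatter, and the most likely outcome for compound 3 is another limit. Compound 3 is estimated at 100000 nM, within 30000 nM to 300000 nM. That estimate means an expected step of a number no higher from compound 2 to compound 3 (the limit leaves the size open).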

Compound 3, half-maximal effective concentration: > 100000 nM
Compound 3 ended at the assay's limit; the forecaster's own chance of this, stated with the estimate: 70%; the middle value sits exactly at the limit.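

In this assay, within the data shown here, compound 3 gives only a limit, so no step among compound 1, compound 2 and compound 3 can be read: the limit of > 100000 nM in this assay, at which 3 of the 3 values shown sit. The compounds shown leave open how these three amide groups truly compare, and which change to the shared core would give a measurable value.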